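The source may hold more compounds than are shown below. What is called first, only, known or untested is meant among the compounds shown, and "the series" means these compounds.

Three compounds share one core and differ only in the group on a saturated chain carbon bound to an aromatic carbon and a double-bonded ring carbon. In an assay on CHO-K1 cells for binding affinity to muscarinic acetylcholine receptor M5 (Homo sapiens) (on this read-out lower numbers stand for stronger inhibition and higher numbers for weaker inhibition), compound 1 `CCC(C1=C(CCN(C)C)Cc2ccccc21)c1ccccn1` gives 676 nM, compound 2 `CCCC(C1=C(CCN(C)C)Cc2ccccc21)c1ccccn1` gives 302 nM, and compound 3 `CN(C)CCC1=C(C(c2ccccc2)c2ccccn2)c2ccccc2C1` gives 66.1 nM. Compound 3 stands lowest of the three, shown by a 4.6-fold lower number from compound 2 to compound 3 (0.66 log units; beyond the scatter) and a 10-fold lower number from compound 1 to compound 3 (1.01 log units; beyond the scatter). Compound 4 `CN(C)CCC1=C(Cc2ccccn2)c2ccccc2C1` carries the change (hydrogen in place of phenyl on a saturated chain carbon bound to an aromatic carbon and a double-bonded ring carbon). The measured steps bear on it from one side only: a 2.2-fold lower number from compound 1 to compound 2 (0.35 log units; beyond the scatter) is a modest gain from a longer chain, while the two steps to the phenyl compound are the largest gains seen. Removing the group altogether goes further toward bareness than any measured compound, so a rise in this assay beyond the scatter is expected, and the number is expected to exceed what compound 1 shows. Compound 4 is therefore expected to give 1500 nM, with a range from 500 nM to 5000 nM. The expected step is then a 23-fold higher number from compound 3 to compound 4 (1.36 log units; beyond the scatter).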

Compound 4, inhibition constant: 3630 nM
Compound 4: the middle estimate sits 2.4-fold (0.38 log units) below what was measured; the range from low to high includes it.
By their numbers in this assay, from the lowest: compound 3; then compound 2; then compound 1; then compound 4.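

The earlier compounds shown here only compared groups with one another, while compound 4 shows what this position gives with hydrogen alone, on the saturated chain carbon bound to an aromatic carbon and a double-bonded ring carbon. In this assay, hydrogen gives a higher number than each of the three groups: ethyl (a 5.4-fold higher number from compound 1 to compound 4 (0.73 log units; beyond the scatter)), propyl (a 12-fold higher number from compound 2 to compound 4 (1.08 log units; beyond the scatter)) and phenyl (a 55-fold higher number from compound 3 to compound 4 (1.74 log units; beyond the scatter)). Among these four compounds, the number falls in the order hydrogen, ethyl, propyl, phenyl, and the replacement of phenyl by hydrogen is the largest change, so this position strongly affects the number in this series.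

From the compounds shown here alone, whether a cyclohexyl ring or a benzyl group would match or pass phenyl remains open. Nothing given here explains why the four compounds fall in this order.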